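The source may hold more compounds than are shown below. What is called first, only, known or untested is meant among the compounds shown, and "the series" means these compounds.

Series notes. Compound 1 `FC(F)(F)c1ccc(CSc2nc(N3CCCCC3)c3ccccc3n2)cc1` gives 25500 nM in a functional assay on PC-3 cells (Homo sapiens) for cytotoxicity, read by MTT assay, with a stated time of 72 h (on this read-out higher numbers stand for weaker inhibition and lower numbers for stronger inhibition), the largest number recorded so far; compound 2 lies within the scatter of it and compound 3 beyond. Compound 2 `FC(F)(F)c1ccc(CSc2nc(Nc3ccccc3Cl)c3ccccc3n2)cc1` gives 20400 nM and compound 3 `FC(F)(F)c1ccc(CSc2nc(Nc3ccc(Cl)cc3)c3ccccc3n2)cc1` gives 7110 nM. Compound 4 `Fc1ccc(Nc2nc(SCc3ccc(C(F)(F)F)cc3)nc3ccccc23)cc1Cl` differs from compound 1 in one place: (3-chloro-4-fluorophenyl)amino in place of piperidin-1-yl on an aromatic carbon. Among the measured compounds shown here, two measured steps bear on this, each exchanging piperidin-1-yl for a chlorophenylamino group: a 1.3-fold lower number from compound 1 to compound 2 (0.10 log units; within the scatter) and a 3.6-fold lower number from compound 1 to compound 3 (0.55 log units; beyond the scatter); between those two products, a 2.9-fold lower number from compound 2 to compound 3 (0.46 log units; beyond the scatter). For the measured compounds named here, the (3-chloro-4-fluorophenyl)amino group entering compound 4 has no measured counterpart, so a modest decrease in number, on the scale of compound 3, is expected. For compound 4 the expected step is a 2.8-fold lower number from compound 1 to compound 4 (0.45 log units; beyond the scatter). Compound 4 is therefore estimated at 9000 nM, within a range from 3500 nM to 23000 nM.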

Compound 4, half-maximal inhibitory concentration: 18600 nM
Estimate against measurement, compound 4: 2.1-fold (0.32 log units) below; the measured number falls inside the stated range.
By their numbers in this assay, from the lowest: compound 3; then compounds 4, 2 and 1 (each within the scatter of the next).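

In this assay, the (3-chloro-4-fluorophenyl)amino group does not separate from piperidin-1-yl at this position, with a 1.4-fold lower number from compound 1 to compound 4 (0.14 log units; within the scatter). It also stays level with the 2-chlorophenyl group on the nitrogen, with a 1.1-fold lower number from compound 2 to compound 4 (0.04 log units; within the scatter), whereas there is a 2.6-fold higher number from compound 3 to compound 4 (0.42 log units; beyond the scatter) and only a modest separation from the 4-chlorophenyl group. An arylamino group at this position therefore brings no general gain over piperidin-1-yl: compound 3 alone departs, and compounds 2 and 4 go against such a pattern.

No evidence is available to explain why compound 3 stands apart. Going by these compounds, whether an unsubstituted phenylamino or a 4-fluorophenylamino group would follow compound 3 or compound 4 remains open.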